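Swapping the aryl group on the core: cytotoxicity outlook

The compounds below may be only part of what the source reports. "The series", "measured", "known", "first", "only" and "open" are said of these compounds alone.

Compound 1 `CN1CCN(CCNCc2cn(-c3ccc(F)cc3F)nc2-c2ccc(OC(F)(F)F)cc2)CC1` is the starting point. In an ADME assay on Huh-7 cells (Homo sapiens) for cytotoxicity (a lower number here means that less compound is tolerated, a higher number that more compound is tolerated), compound 1 gives 18000 nM, the highest of the two measured numbers. Compound 2 `CN1CCN(CCNCc2cn(-c3ccc([N+](=O)[O-])cc3)nc2-c2ccc(OC(F)(F)F)cc2)CC1` gives 4400 nM, and the step of a 4.1-fold lower number from compound 1 to compound 2 (0.61 log units; beyond the scatter) shows that the 4-nitrophenyl change lowers the amount tolerated. Compound 3 `Cc1ccccc1-c1nn(-c2ccc(F)cc2F)cc1CNCCCN1CCN(C)CC1` reaches only a limit of the assay, > 20000 nM, as recorded in the limit of > 20000 nM in this assay, at which 1 of the 3 values shown sits. Compound 4 `CN1CCN(CCNCc2cn(-c3ccc(F)cc3F)nc2-c2ccccc2Cl)CC1` differs from compound 1 by 2-chlorophenyl in place of 4-(trifluoromethoxy)phenyl on an aromatic carbon. Going by the values given here, no measured step touches this position, so for compound 4 the step of a 1.1-fold higher number from compound 1 to compound 4 (0.05 log units; within the scatter) is expected to remain within the scatter, with a fair chance that only a limit is reported. The estimate for compound 4 is 20000 nM, between 9000 nM and 45000 nM.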

Compound 4, half-maximal cytotoxic concentration: > 20000 nM
Compound 4: a limit, no number (the forecaster's own chance of this, stated with the estimate: 45%); the middle value lies on the limit itself.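

Going by these compounds alone, this is the first measured change at this position on the shared core: 2-chlorophenyl in place of 4-(trifluoromethoxy)phenyl gives an at least 1.1-fold higher number from compound 1 to compound 4 (0.04 log units; that floor lies within the scatter) in this assay. No loss in the amount tolerated appears with this change, so this position accepts a smaller chlorine-bearing phenyl here. The reading for compound 4 is a limit and not a number, which leaves the true size of the step unknown: the limit of > 20000 nM in this assay, at which 2 of the 4 values shown sit.

Still open, on these data alone, is how a phenyl group carrying an amine or a carboxylic acid would read at this position. Also open, as far as these compounds go, is whether 2-chlorophenyl would behave the same alongside 4-nitrophenyl on the aromatic nitrogen.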